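From Dimethylamino to Methyl on a Shared Core

This account rests on a few compounds, and the source may have more. Where it says the series, first, only, none or still open, it means among the compounds named here.

Of the compounds shown here, three built on one shared core have been measured in a physicochemical assay for lipophilicity; a higher number here means a more lipophilic compound, a lower number a more polar compound. Compound 1 `COc1cc(/C=C2\CCC/C(=C\c3ccccc3[N+](=O)[O-])C2=O)cc(OC)c1OC` gives 4.86. Compound 2 `CN(C)c1ccc(/C=C2\CCC/C(=C\c3ccccc3[N+](=O)[O-])C2=O)cc1` gives 4.86, level with compound 1 at the digits shown, so that these two share the lowest number of the three. Compound 3 `O=C1/C(=C/c2ccccc2)CCC/C1=C\c1cccc([N+](=O)[O-])c1` gives 5.06, a number that lies within the usual scatter of the value of compound 2, so nothing separates the two compounds in this assay.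

The next compound, compound 4 `Cc1ccc(/C=C2\CCC/C(=C\c3ccccc3[N+](=O)[O-])C2=O)cc1`, follows from compound 2 by a single change: methyl in place of dimethylamino on an aromatic carbon. No step of this kind has been measured among the compounds shown, so the expectation rests only on the values of compound 2 and compound 3 and on the change itself. Compound 4 is expected to give 5.25, with a range from 4.9 to 5.6. The step of a number 0.39 log units higher from compound 2 to compound 4 (beyond the scatter) that this estimate means is expected to be a small rise, just beyond the scatter of this assay, with the direction held more firmly than the size.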

Compound 4, partition coefficient: 4.86
For compound 4 the middle estimate is 0.39 log units above the measured one, and the stated range ends above it.
By their numbers in this assay, from the lowest: compounds 1, 2, 4 and 3 (each within the scatter of the next).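

In this assay, putting methyl in place of dimethylamino on this aromatic carbon gives no change at the digits printed from compound 2 to compound 4 (within the scatter). This is the first pair among the compounds shown that differs in only one place, so it is the first direct reading of a single change on the shared core: the group that leaves has 3 heavy atoms, including a nitrogen, and 1 hydrogen-bond acceptor, the group that enters has 1 heavy atom and 0 hydrogen-bond acceptors, and this difference in the groups does not show in the number. Nothing available here accounts for this outcome.

This is a single step at a single position, so it sets no rule for the position, and it cannot say whether the number would stay level with a carboxylic acid, a primary amine or a longer chain such as butyl in the same place. From the compounds shown here alone, whether the same change would read alike on a compound with a different group on the other side of the shared core also remains open.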